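The compounds below may be only part of what the source reports. "The series", "measured", "known", "first", "only" and "open" are said of these compounds alone.

Measured so far in a functional assay on HCT-116 cells (Homo sapiens) for inhibition, with a stated time of 72 h; a higher number here means a weaker inhibitor, a lower number a stronger inhibitor:
- compound 1 `NC1CCC(Nc2nc(NCc3ccc(Br)cc3)c3ncn(C4CCCC4)c3n2)CC1` gives 790 nM
- compound 2 `NC1CCC(Nc2nc(NCc3ccc(-c4ccccc4)cc3)c3ncn(C4CCCC4)c3n2)CC1` gives 745 nM
- compound 3 `NC1CCC(Nc2nc(NCc3ccc(-c4ccsc4)cc3)c3ncn(C4CCCC4)c3n2)CC1` gives 315 nM

Compound 3 has the lowest number of the three, which makes it the strongest inhibitor so far. Compound 4 `NC1CCC(Nc2nc(NCc3ccc(-c4ccccc4)nc3)c3ncn(C4CCCC4)c3n2)CC1` has not been measured yet. It has 6-phenylpyridin-3-yl in place of 4-(thiophen-3-yl)phenyl on a saturated chain carbon bound to a nitrogen on an aromatic ring.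

Among the compounds with values here, three measured steps bear on this change. Swapping bromo for phenyl gave a 1.1-fold lower number from compound 1 to compound 2 (0.03 log units; within the scatter), which is no real change. Swapping phenyl for thiophen-3-yl gave a 2.4-fold lower number from compound 2 to compound 3 (0.37 log units; beyond the scatter), a modest step, and swapping bromo for thiophen-3-yl gave a 2.5-fold lower number from compound 1 to compound 3 (0.40 log units; beyond the scatter), which is similar in size. Compound 4 gives up the thiophen-3-yl and carries a phenyl, as compound 2 does, so the modest step of a 2.4-fold lower number from compound 2 to compound 3 (0.37 log units; beyond the scatter) may be partly undone. Within the data shown here, no measured compound contains a pyridine ring, so that part of the change is untested. A small move toward a higher number is therefore expected, possibly no larger than the scatter.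

The expected step is a 1.4-fold higher number from compound 3 to compound 4 (0.15 log units; within the scatter).

For compound 4 the estimated value is 450 nM, with an expected range from 150 nM to 1300 nM.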

Compound 4, half-maximal inhibitory concentration: 563 nM
For compound 4 the middle estimate is 1.3-fold (0.10 log units) below the measured one; the measured number falls inside the stated range.
By their numbers in this assay, from the lowest: compounds 3, 4, 2 and 1 (each within the scatter of the next, the first and the last beyond it).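

In this assay, within the data shown here, a pyridine ring appears at this place for the first time, and swapping 4-phenylphenyl for 6-phenylpyridin-3-yl gives a 1.3-fold lower number from compound 2 to compound 4 (0.12 log units; within the scatter), so this closest comparison shows no real change. The other two steps, a 1.4-fold lower number from compound 1 to compound 4 (0.15 log units; within the scatter) and a 1.8-fold higher number from compound 3 to compound 4 (0.25 log units; within the scatter), also lie within the scatter, which leaves the pyridine compound inseparable from each of the three earlier compounds, even though compound 3 stands apart from compound 1 and compound 2 by steps beyond the scatter. This place on the saturated chain carbon therefore accepts a six-membered aromatic ring with one hetero atom with no loss that can be told from the scatter, and no outside measurement is available to explain the result.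

Still open, as far as these compounds go, is whether a pyridine ring carrying thiophen-3-yl would match compound 3 or fall back toward the others, since thiophen-3-yl and pyridine never occur together in these compounds. Also open, from the compounds shown here alone, is how this assay would respond to a carboxylic acid, an amine or a morpholine in place of the phenyl on the pyridine ring.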